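Thiophene in place of fluorohydroxyphenyl on the hydrazone carbon

The source may hold more compounds than are shown below. What is called first, only, known or untested is meant among the compounds shown, and "the series" means these compounds.

Measured so far in a functional assay on PC-3 cells (Homo sapiens) for antiproliferative activity, read by MTT assay; a higher number here means a weaker inhibitor, a lower number a stronger inhibitor:
compound 1 `Cc1cccc(/C=N/Nc2ncc3c(n2)n(C2CCCC2)c(=O)c(=O)n3C)c1` gives 53600 nM
compound 2 `Cn1c(=O)c(=O)n(C2CCCC2)c2nc(N/N=C/c3ccc(F)c(Cl)c3)ncc21` gives 8550 nM
compound 3 `Cn1c(=O)c(=O)n(C2CCCC2)c2nc(N/N=C/c3ccc(O)c(F)c3)ncc21` gives 85200 nM

Compound 3 has the highest number of the three in this assay; the gap to compound 1 lies within the scatter, while the other gap lies beyond it (a 10-fold higher number from compound 2 to compound 3 (1.00 log units; beyond the scatter)). Compound 4 `Cn1c(=O)c(=O)n(C2CCCC2)c2nc(N/N=C/c3cccs3)ncc21` differs from compound 3 in one place: thiophen-2-yl in place of 3-fluoro-4-hydroxyphenyl on a carbon with a double bond to nitrogen. Among the compounds with values here, no measured step swaps this ring for a five-membered one, so the bearing steps are only the aryl exchanges on the same carbon: a 6.3-fold lower number from compound 1 to compound 2 (0.80 log units; beyond the scatter), a 1.6-fold higher number from compound 1 to compound 3 (0.20 log units; within the scatter) and a 10-fold higher number from compound 2 to compound 3 (1.00 log units; beyond the scatter). Both rings without a hydrogen-bond donor sit at or below compound 3, so compound 4 is expected to give a modestly lower number, a 2.8-fold lower number from compound 3 to compound 4 (0.45 log units; beyond the scatter), with wide uncertainty. The estimate for compound 4 is 30000 nM, range 8000 nM to 120000 nM.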

Compound 4, half-maximal inhibitory concentration: 75600 nM
Beside the measured number, compound 4's estimate is 2.5-fold (0.40 log units) below it; the measured number falls inside the stated range.
By their numbers in this assay, from the lowest: compound 2; then compounds 1, 4 and 3 (each within the scatter of the next).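

In this assay, thiophen-2-yl on this carbon with a double bond to nitrogen reads level with 3-fluoro-4-hydroxyphenyl (a 1.1-fold lower number from compound 3 to compound 4 (0.05 log units; within the scatter)) and with 3-methylphenyl (a 1.4-fold higher number from compound 1 to compound 4 (0.15 log units; within the scatter)), so a five-membered aromatic ring fits the same group as these two six-membered rings. Only 3-chloro-4-fluorophenyl stands apart (an 8.8-fold higher number from compound 2 to compound 4 (0.95 log units; beyond the scatter)), leaving compound 2 the strongest of the four. Nothing available accounts for these results.

Open, as far as these compounds go, is whether a chlorine on the thiophene ring would bring compound 4 nearer to compound 2, and how an aryl ring carrying an amine or a carboxylic acid would read at this carbon.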